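Swapping a Carbamoyl for 2-Carboxyethyl on a Silylated Nucleoside

A few compounds are considered here, and "the series" means these few. Any claim that something is new, unique, unknown or untested is made for them only; others in the source may bear on it.

Measured in a functional assay on MT4 cells (Homo sapiens); a lower number here means that less compound is tolerated, a higher number that more compound is tolerated:
- Compound 1 `Cc1cn([C@@H]2O[C@@H]3COC(=O)[C@]3(OS(C)(=O)=O)[C@H]2O)c(=O)[nH]c1=O`: >= 250000 nM, a limit of the assay
- Compound 2 `Cc1cn([C@@H]2O[C@H](CO[Si](C)(C)C(C)(C)C)[C@@]3(OS(=O)(=O)C=C3NC(N)=O)[C@H]2O[Si](C)(C)C(C)(C)C)c(=O)n(C)c1=O`: 3700 nM
- Compound 3 `Cc1cn([C@@H]2O[C@@H]3COC4(O)CS(=O)(=O)O[C@@]34[C@H]2O[Si](C)(C)C(C)(C)C)c(=O)[nH]c1=O`: 100000 nM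

Of the two values that are true numbers, compound 2 has the lower, and the gap to compound 3 lies beyond the scatter. Compound 4 `Cc1cn([C@@H]2O[C@H](CO[Si](C)(C)C(C)(C)C)[C@@]3(OS(=O)(=O)C=C3NCCC(=O)O)[C@H]2O[Si](C)(C)C(C)(C)C)c(=O)n(C)c1=O` carries 2-carboxyethyl in place of carbamoyl on an amine nitrogen. Among the measured compounds shown here, no measured pair shows a change of this kind, so any forecast is tentative. With compound 2 at 3700 nM, the low end of the numbers seen, a shift toward more tolerated compound seems likelier than the reverse. The expected step is a 4.1-fold higher number from compound 2 to compound 4 (0.61 log units; beyond the scatter), a moderate rise. Compound 4 is estimated at 15000 nM, with an expected range of 4000 nM to 60000 nM.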

Compound 4, half-maximal cytotoxic concentration: 11500 nM
Compound 4: the middle estimate sits 1.3-fold (0.12 log units) above what was measured, within the range that was stated.
By their numbers in this assay, from the lowest: compound 2; then compound 4; then compound 3. At a limit, above all of these: compound 1.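

In this assay, the amine nitrogen on the double-bonded ring carbon proves sensitive to substitution: 2-carboxyethyl in place of carbamoyl gives a 3.1-fold higher number from compound 2 to compound 4 (0.49 log units; beyond the scatter), a modest step. This is the first change in one place among these compounds, so the effect of this position can now be read directly, though from a single step. Nothing available explains the shift.

From the compounds shown here alone, whether the step follows from the carboxylic acid or from the longer chain remains open, and a methyl ester or a plain propyl chain on the same nitrogen would separate the two. Going by these compounds, how a primary amine at the end of that chain would compare also remains open.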